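Thiophen-2-yl for furan-3-yl at the assay limit

The source may report more compounds than this note shows. Statements on the series, on what has been measured and on what is new or still open speak of the compounds shown alone.

Compound 1 `CSc1ncnc2c1c(-c1cccs1)cn2[C@@H]1O[C@H](CO)[C@@H](O)[C@H]1O`: > 20000 nM, a limit
Compound 2 `CNc1ncnc2c1c(-c1cccs1)cn2[C@@H]1O[C@H](CO)[C@@H](O)[C@H]1O`: > 20000 nM, a limit
Compound 3 `Cc1ncnc2c1c(-c1ccoc1)cn2[C@@H]1O[C@H](CO)[C@@H](O)[C@H]1O`: > 20000 nM, a limit

In a functional assay on HCT-116 cells (Homo sapiens), read by MTT assay, with a stated time of 72 h (a higher number here means a weaker inhibitor, a lower number a stronger inhibitor), compound 3 gives > 20000 nM, which is a limit and not a number. Within the data shown here, the same holds for every compound measured so far, and the data amount to the limit of > 20000 nM in this assay, at which 3 of the 3 values shown sit. Compound 4 `Cc1ncnc2c1c(-c1cccs1)cn2[C@@H]1O[C@H](CO)[C@@H](O)[C@H]1O` is the next to be read, and it differs from compound 3 in one place: thiophen-2-yl in place of furan-3-yl on an aromatic carbon.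

Among the measured compounds shown here, no measured step covers this change. The only one, a step that the two limits leave unreadable from compound 1 to compound 2, concerns methylamino in place of methylsulfanyl and gives no size to carry over. Compound 1 and compound 2 already carry thiophen-2-yl, and neither gives a number in this assay.

The estimated change, an at least 1.3-fold lower number from compound 3 to compound 4 (0.12 log units; that floor lies within the scatter), is therefore expected to be modest, and a limit is again the likeliest report. Any number that does appear is expected to lie on the stronger side of the limit. For compound 4 the estimate is 15000 nM, with an expected range of 2000 nM to 20000 nM.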

Compound 4, half-maximal inhibitory concentration: > 20000 nM
Compound 4: only a limit was reported; the forecaster's own chance of this, stated with the estimate: 60%; at least 1.3-fold (0.12 log units) between middle value and limit.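

In this assay, among these compounds, compound 4 gives > 20000 nM, a limit and not a number, so no step from compound 1, compound 2 or compound 3 to compound 4 can be read. The compounds shown leave open whether any of these exchanged groups changes the result in this assay, and the data end at one value: the limit of > 20000 nM in this assay, at which 4 of the 4 values shown sit.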